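This account rests on a few compounds, and the source may have more. Where it says the series, first, only, none or still open, it means among the compounds named here.

The three measured compounds share one core and differ only in the group carried on an amine nitrogen in a ring. Compound 1 `Nc1ccccc1NC(=O)c1ccc(CSC(=S)N2CCN(c3ccccc3)CC2)cc1` carries phenyl there, and in a functional assay on A-375 cells (Homo sapiens) for antiproliferative activity, read by CCK-8 assay, with a stated time of 72 h, tested at 8 uM (a lower number here means a weaker effect, a higher number a stronger effect of the compound at the concentration tested), compound 1 gives 88.6%. Compound 2 `Nc1ccccc1NC(=O)c1ccc(CSC(=S)N2CCN(c3cccnc3)CC2)cc1` carries pyridin-3-yl, and in this assay compound 2 gives 88.8%. Compound 3 `Nc1ccccc1NC(=O)c1ccc(CSC(=S)N2CCN(Cc3ccncc3)CC2)cc1` carries (pyridin-4-yl)methyl, and in this assay compound 3 gives 89.5%. Compound 3 stands at the top of the three numbers, but its margins over the others are a number 0.9 percentage points higher from compound 1 to compound 3 (within the scatter) and a number 0.7 percentage points higher from compound 2 to compound 3 (within the scatter), both within the scatter, so the three compounds cannot be told apart on these data.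

The unmeasured compound 4 `Nc1ccccc1NC(=O)c1ccc(CSC(=S)N2CCN(c3ncccn3)CC2)cc1` alters the same position: pyrimidin-2-yl in place of (pyridin-4-yl)methyl on an amine nitrogen in a ring. For the measured compounds named here, the steps that bear on this change are the three earlier exchanges at that nitrogen, a number 0.2 percentage points higher from compound 1 to compound 2 (within the scatter), a number 0.9 percentage points higher from compound 1 to compound 3 (within the scatter) and a number 0.7 percentage points higher from compound 2 to compound 3 (within the scatter), none of which went beyond the scatter. Going by the values given here, every group tried at this position so far has left the read-out essentially unchanged, and no step among the measured compounds points in either direction. The expectation is therefore a step of a number 1 percentage points lower from compound 3 to compound 4 (within the scatter), meaning nothing beyond the scatter. Compound 4 is expected to give 88.5% in this assay, with a range from 82% to 93%.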

Compound 4, a percentage reported as inhibition, at one concentration (the size of the read-out at that concentration, not a potency): 67.9%
For compound 4 the middle estimate is 20.6 percentage points above the measured one, and the stated range ends above it.
By their numbers in this assay, from the lowest: compound 4; then compounds 1, 2 and 3 (each within the scatter of the next).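

The position on the ring nitrogen is not indifferent after all: the exchange for pyrimidin-2-yl gives a number 21.6 percentage points lower from compound 3 to compound 4 (beyond the scatter) and a number 20.9 percentage points lower from compound 2 to compound 4 (beyond the scatter) and also a number 20.7 percentage points lower from compound 1 to compound 4 (beyond the scatter) in this assay while phenyl, pyridin-3-yl and (pyridin-4-yl)methyl remain within the scatter of one another. Compared with (pyridin-4-yl)methyl, the entering group is a directly attached six-membered aromatic ring with 2 hetero atoms and 2 hydrogen-bond acceptors, yet pyridin-3-yl, also attached directly, keeps its value, so direct attachment of an aromatic ring does not by itself go with the loss. No measurement given here accounts for the loss.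

The compounds shown leave open whether the loss belongs to pyrimidin-2-yl alone or would also appear with pyridin-2-yl, pyrazin-2-yl or pyrimidin-5-yl, which would show whether the number of ring nitrogens or their placement goes with it. Since the read-out is taken at a single concentration on a single cell line, they also leave open how large the difference in potency is and whether it would hold on other cells.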